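The source may report more compounds than this note shows. Statements on the series, on what has been measured and on what is new or still open speak of the compounds shown alone.

Measured in a functional assay on SNO cells (Homo sapiens) for cytotoxicity, read by XTT assay, with a stated time of 24 h; on this read-out higher numbers stand for weaker inhibition and lower numbers for stronger inhibition:
- compound 1 `COc1c(C)cc(Cl)c2c1C(=O)C=CC2=O`: 44900 nM
- compound 2 `Cc1cc(O)c2c(c1Cl)C(=O)C=CC2=O`: 17200 nM
- compound 3 `Cc1cc(O)c2c(c1F)C(=O)C=CC2=O`: 18900 nM

Compound 3 stands level with compound 2 within the scatter, while compound 1, at 44900 nM, gives a higher number than either. Compound 4 `Cc1cc(O)c2c(c1Br)C(=O)C=CC2=O` has not yet been measured. It differs from compound 3 by bromo in place of fluoro on an aromatic carbon. Going by the values given here, the one measured step that bears on this change, fluoro in place of chloro, is a 1.1-fold higher number from compound 2 to compound 3 (0.04 log units; within the scatter). On that evidence, no step beyond the scatter is expected in this assay, and no direction is clearly favoured. The expected change is a 1.2-fold lower number from compound 3 to compound 4 (0.07 log units; within the scatter). Compound 4 is estimated at 16000 nM, with an expected range of 8000 nM to 32000 nM.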

Compound 4, half-maximal inhibitory concentration: 14900 nM
Beside the measured number, compound 4's estimate is 1.1-fold (0.03 log units) above it; measured number inside the range.
By their numbers in this assay, from the lowest: compounds 4, 2 and 3 (each within the scatter of the next); then compound 1.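

In this assay, bromo at this position, para to a hydroxy group, gives a 1.3-fold lower number from compound 3 to compound 4 (0.10 log units; within the scatter) and a 1.2-fold lower number from compound 2 to compound 4 (0.06 log units; within the scatter). Fluoro, chloro and bromo therefore all stand level here within the scatter, extending what the single earlier step showed for fluoro and chloro alone. Nothing available explains this result. The compounds shown leave open whether a group other than a halogen at this position, such as an amine or a nitrile, would give a step beyond the scatter.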